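Swapping a Nitrile-Bearing Ring for a Fluorinated One

A few compounds are considered here, and "the series" means these few. Any claim that something is new, unique, unknown or untested is made for them only; others in the source may bear on it.

Compound 1 `Cc1cccc(NC(=O)CN2CCC(c3ccccc3C#N)CC2)c1` was tested in a functional assay on HEK293 cells for agonist activity at D(4) dopamine receptor (Homo sapiens), read by FLIPR (on this read-out lower numbers stand for smaller maximal responses and higher numbers for larger maximal responses), where compound 1 gives 71%. Among the three measured compounds this is the highest of the numbers: compound 3 `Oc1ccc(N2CCN(Cc3nc4ccccc4[nH]3)CC2)nc1` gives 70%, which lies within the usual scatter of compound 1, while compound 2 `CSc1cccc(NC(=O)CN2CCC(c3cccc[n+]3[O-])CC2)c1` gives 56%, a number beyond that scatter. Compound 4 `Cc1cccc(NC(=O)CN2CCC(c3cccc(F)c3)CC2)c1` has not yet been measured. It differs from compound 1 in one place: 3-fluorophenyl in place of 2-cyanophenyl on a saturated ring carbon. Among the measured compounds shown here, no measured pair shows the effect of such a swap, so any expectation rests on compound 1 alone. The response of compound 4 is expected to stay close to that of compound 1, with a step of a number 5 percentage points lower from compound 1 to compound 4 (within the scatter) that would not exceed the scatter. Compound 4 is therefore estimated at 66%, within 46% to 86%.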

Compound 4, largest response reached (reported as efficacy), in percent of the reference or control that the assay uses: 40%
Estimate against measurement, compound 4: 26 percentage points above; the measured number lies below the stated range.
By their numbers in this assay, from the lowest: compound 4; then compound 2; then compounds 3 and 1 (each within the scatter of the next).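

Among the compounds shown here, this is the first measured pair that differs in one place. In this assay, 3-fluorophenyl in place of 2-cyanophenyl gives a number 31 percentage points lower from compound 1 to compound 4 (beyond the scatter), so the maximal response depends strongly on the group at this saturated ring carbon. No measurement at hand gives a cause for this step.

The swap alters both the substituent and where it sits on the phenyl ring, so these two changes cannot be separated. A plain phenyl, 2-fluorophenyl or 3-cyanophenyl group at this carbon would show which change matters.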